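This account rests on a few compounds, and the source may have more. Where it says the series, first, only, none or still open, it means among the compounds named here.

In a physicochemical assay for solubility, read by turbidimetry, measured as kinetic solubility, at pH 6.8 (on this read-out lower numbers stand for lower solubility and higher numbers for higher solubility), compound 1 `COc1ccc(F)cc1N1C(=O)CSC1c1cccc(C(=O)NCCCCn2cccn2)c1` gives 50000 nM and compound 2 `Cc1cccc(N2C(=O)CSC2c2cccc(C(=O)NCCCCc3ccccc3)c2)c1` gives 10000 nM. Compound 2 therefore holds the lower of the two numbers, with a gap beyond the usual scatter. Compound 3 `O=C(NCCCCc1ccccc1)c1cccc(C2SCC(=O)N2c2cccc(F)c2)c1` has not yet been measured. It differs from compound 2 in one place: fluoro in place of methyl on an aromatic carbon. Within the data shown here, no measured pair shows this change. A small upward step in this assay, not beyond the usual scatter, is expected. The estimated step is a 1.4-fold higher number from compound 2 to compound 3 (0.15 log units; within the scatter). The expected value for compound 3 is 14000 nM, with a range from 6000 nM to 40000 nM.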

Compound 3, solubility: 10000 nM
Compound 3: the middle estimate sits 1.4-fold (0.15 log units) above what was measured, and the stated range covers the measured number.
By their numbers in this assay, from the lowest: compounds 2 and 3 (each within the scatter of the next); then compound 1.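

In this assay, putting fluoro in place of methyl on this aromatic carbon, which turns 3-methylphenyl into 3-fluorophenyl, gives no change at the digits printed from compound 2 to compound 3 (within the scatter). Among these compounds, this is the first pair of compounds here that differ in one place, and it shows that the two groups cannot be told apart at this position on this read-out. No measurement at hand offers an explanation for this result. Still open, on these data alone, is whether an amine or a carboxylic acid on the same carbon would separate from these values, and whether the same change reads alike on other compounds.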